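A few compounds are considered here, and "the series" means these few. Any claim that something is new, unique, unknown or untested is made for them only; others in the source may bear on it.

Measured so far:
compound 1, `Cc1ccc(CN2C(=O)N(c3ccc(Cl)cc3)C(=O)C2CCC(=O)NCc2ccc(C(=O)NO)cc2)cc1` — 18.9 nM
compound 2, `O=C(CCC1C(=O)N(c2ccc(Cl)cc2)C(=O)N1Cc1ccccc1)Nc1ccc(C(=O)NO)cc1` — 7.6 nM

Of the compounds shown here, two have been tested in an assay on isolated protein for inhibition of protein deacetylase HDAC6 (Homo sapiens), read by fluorescence, with stated times of 5 min and 60 min; on this read-out higher numbers stand for weaker inhibition and lower numbers for stronger inhibition. Compound 1, `Cc1ccc(CN2C(=O)N(c3ccc(Cl)cc3)C(=O)C2CCC(=O)NCc2ccc(C(=O)NO)cc2)cc1`, gives 18.9 nM. Compound 2, `O=C(CCC1C(=O)N(c2ccc(Cl)cc2)C(=O)N1Cc1ccccc1)Nc1ccc(C(=O)NO)cc1`, gives 7.6 nM. Among the measured compounds shown here, compound 2 therefore holds the lowest of the two numbers; the only other compound, compound 1, stands higher, and that gap lies beyond the usual scatter of repeated measurements.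

The next compound, compound 3, `O=C(CCC1C(=O)N(c2ccc(Cl)cc2)C(=O)N1Cc1ccccc1)NCc1ccc(C(=O)NO)cc1`, is obtained from compound 2 by a single change: 4-(hydroxycarbamoyl)benzyl in place of 4-(hydroxycarbamoyl)phenyl on an amide-type nitrogen. The rest of the structure, including the benzyl group on the core and the chloro-substituted phenyl group, is kept.

For the measured compounds named here, no pair of measured compounds differs in this way alone, so no measured step tells what this change does. Compound 1 already carries the 4-(hydroxycarbamoyl)benzyl group on its amide nitrogen and in this assay compound 1 gives 18.9 nM. On that basis compound 3 is expected to sit nearer compound 1 than compound 2, the step of a 2.2-fold higher number from compound 2 to compound 3 (0.35 log units; beyond the scatter) being expected to go toward weaker inhibition. The estimate for compound 3 in this assay is 17 nM, within 6 nM to 45 nM.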

Compound 3, half-maximal inhibitory concentration: 12.7 nM
Beside the measured number, compound 3's estimate is 1.3-fold (0.13 log units) above it, and the stated range covers the measured number.
By their numbers in this assay, from the lowest: compounds 2, 3 and 1 (each within the scatter of the next, the first and the last beyond it).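

In this assay, the change on the amide-type nitrogen, 4-(hydroxycarbamoyl)benzyl in place of 4-(hydroxycarbamoyl)phenyl, gives a 1.7-fold higher number from compound 2 to compound 3 (0.22 log units; within the scatter), so this position takes the group with one more carbon without a difference that can be told from repeated measurement. Among the compounds shown here, the first one-place comparison at the benzyl group on the core, hydrogen in place of methyl on an aromatic carbon, gives a 1.5-fold lower number from compound 1 to compound 3 (0.17 log units; within the scatter), and this change likewise cannot be told apart from the scatter. Nothing at hand offers an explanation for either step.

The compounds shown carry only these two groups on the amide-type nitrogen, so it stays open how a longer chain, such as 4-(hydroxycarbamoyl)phenethyl, would read in this assay. On these data alone, it also stays open whether a methoxy group or a chlorine on that benzyl group, or a carboxylic acid in place of the hydroxycarbamoyl group, would give a step beyond the scatter.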